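Swapping the Naphthyl Group of Compound 2 for Trifluoromethylphenyl

The source may hold more compounds than are shown below. What is called first, only, known or untested is meant among the compounds shown, and "the series" means these compounds.

Compound 1 `CCCCCCCCn1cc(COC2(C(F)(F)F)Oc3ccccc3C=C2C(=O)OCC)nn1` — in a functional assay on HeLa cells (Homo sapiens) for inhibition, read by MTT assay, with a stated time of 24 h (on this read-out higher numbers stand for weaker inhibition and lower numbers for stronger inhibition), compound 1 gives only a limit, > 150000 nM.
Compound 2 `CCOC(=O)C1=Cc2ccccc2OC1(OCc1cc(-c2ccc3ccccc3c2)no1)C(F)(F)F` — in this assay compound 2 gives only a limit, > 150000 nM.
Compound 3 `O=C(O)C1=Cc2ccccc2OC1(OCc1cc(-c2ccc3ccccc3c2)no1)C(F)(F)F` — in this assay compound 3 gives only a limit, > 150000 nM.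

In this assay compound 2 therefore stands at the assay's limit, not at a measured number. For the measured compounds named here, the one step among the measured compounds, a step that the two limits leave unreadable from compound 2 to compound 3, runs between two limits and cannot be read, as the limit of > 150000 nM in this assay, at which 3 of the 3 values shown sit, summarizes. Compound 4 `CCOC(=O)C1=Cc2ccccc2OC1(OCc1cc(-c2cccc(C(F)(F)F)c2)no1)C(F)(F)F` differs from compound 2 in a single place: 3-(trifluoromethyl)phenyl in place of naphthalen-2-yl on an aromatic carbon. Going by the values given here, no measured step bears on this change. Because the limit of > 150000 nM in this assay, at which 3 of the 3 values shown sit, shows every value at the limit, compound 4 is expected to remain at the limit as well. The step that the limit leaves unreadable from compound 2 to compound 4 is expected to be none beyond the scatter. Compound 4 is estimated at 200000 nM, between 100000 nM and 400000 nM.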

Compound 4, half-maximal inhibitory concentration: 21400 nM
Beside the measured number, compound 4's estimate is 9.3-fold (0.97 log units) above it, outside the stated range (below it).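

Placing 3-(trifluoromethyl)phenyl instead of naphthalen-2-yl on the aromatic carbon next to the ring nitrogen gives an at least 7.0-fold lower number from compound 2 to compound 4 (0.84 log units; beyond the scatter) in this assay, which means stronger inhibition. For the compounds shown here, this position can therefore change the read-out, which the earlier compounds could not show. Compound 4 is the only compound here with a measured number rather than a limit: the limit of > 150000 nM in this assay, at which 3 of the 4 values shown sit.

The change both removes an aromatic ring and adds a trifluoromethyl group, and the compounds shown do not separate these two parts. On these data alone, an unsubstituted phenyl or a 3-chlorophenyl at this position remains open.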